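Hydroxy Added Ortho on a Chalcone Core

This account rests on a few compounds, and the source may have more. Where it says the series, first, only, none or still open, it means among the compounds named here.

Compound 1 `O=C(/C=C/c1ccc(F)cc1)c1ccccc1`: in a functional assay on RAW264.7 cells (Mus musculus) for inhibition, read by fluorescence, with stated times of 1 h, 24 h and 30 min (a lower number here means a stronger inhibitor, a higher number a weaker inhibitor), compound 1 reaches only the limit > 10000 nM.
Compound 2 `O=C(/C=C/c1ccc(F)cc1)c1cccc(O)c1`: in this assay compound 2 likewise gives only the limit > 10000 nM.
Compound 3 `O=C(/C=C/c1ccc(OC(F)(F)F)cc1)c1ccccc1`: in this assay compound 3 again gives only the limit > 10000 nM.

All three measured values sit at the same limit, as the limit of > 10000 nM in this assay, at which 3 of the 3 values shown sit, records. The step from compound 1 to compound 2 a step that the two limits leave unreadable from compound 1 to compound 2 is therefore unreadable; the change behind it is hydroxy in place of hydrogen on an aromatic carbon. The core of compound 3 differs from that of compound 1 by trifluoromethoxy in place of fluoro on an aromatic carbon, a step that the two limits leave unreadable from compound 1 to compound 3 also left unreadable.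

Compound 4 `O=C(/C=C/c1ccc(OC(F)(F)F)cc1)c1ccccc1O` has not yet been measured. It arises from compound 3 by hydroxy in place of hydrogen on an aromatic carbon, the same kind of change as from compound 1 to compound 2, though there the hydroxy sits meta to a large group and here ortho to a large group. Since compound 3 gives only a limit > 10000 nM, the step that the limit leaves unreadable from compound 3 to compound 4 is expected to stay unreadable, and compound 4 is estimated at 15000 nM, between 4000 nM and 60000 nM.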

Compound 4, half-maximal inhibitory concentration: > 10000 nM
Compound 4: no number, only a limit; the forecaster's own chance of this, stated with the estimate: 80%; the middle value does not contradict the limit.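

Compound 4, like compound 3, gives only a limit, so no step between compound 3 and compound 4 can be read: the limit of > 10000 nM in this assay, at which 4 of the 4 values shown sit.

The compounds shown leave open whether hydroxy in place of hydrogen on an aromatic carbon changes inhibition in this assay at all.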